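A Fluorobenzyl Exchange Carried to a Second Core

The source may report more compounds than this note shows. Statements on the series, on what has been measured and on what is new or still open speak of the compounds shown alone.

Of the compounds shown here, three of one series have been tested in a functional assay on HL-60 cells (Homo sapiens) for cytotoxicity, read by MTT assay, with a stated time of 48 h; a higher number here means a weaker inhibitor, a lower number a stronger inhibitor. Compound 1 `Cc1ccc(Cn2c(/C=C3\SC(=S)N(CC(=O)O)C3=O)nc3cc(Cl)ccc32)cc1` gives 2720 nM. Compound 2 `Cc1ccc(Cn2c(/C=C3\SC(=S)N(CC(=O)O)C3=O)nc3ccc(Cl)cc32)cc1` shares the same atoms as compound 1 joined differently, a difference between the two cores that is not broken down here, and compound 2 gives 2840 nM; the two values lie within the scatter of each other. Compound 3 `O=C(O)CN1C(=O)/C(=C/c2nc3cc(Cl)ccc3n2Cc2ccccc2F)SC1=S` gives 870 nM. Compound 3 arises from compound 1 by a single change, (2-fluorophenyl in place of 4-methylphenyl on a saturated chain carbon bound to an aromatic nitrogen), and that change produced a 3.1-fold lower number from compound 1 to compound 3 (0.50 log units; beyond the scatter).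

Compound 4 `O=C(O)CN1C(=O)/C(=C/c2nc3ccc(Cl)cc3n2Cc2ccccc2F)SC1=S` has not yet been measured. It arises from compound 2 by the same change, (2-fluorophenyl in place of 4-methylphenyl on a saturated chain carbon bound to an aromatic nitrogen), made at the same place. Compound 1 and compound 2 sit within the scatter of each other in this assay, so the change is expected to carry over with a similar size. For compound 4 the estimated step is a 3.0-fold lower number from compound 2 to compound 4 (0.48 log units; beyond the scatter), because the same change produced a 3.1-fold lower number from compound 1 to compound 3 (0.50 log units; beyond the scatter). Compound 4 is therefore estimated at 950 nM, with a likely range from 450 nM to 2000 nM.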

Compound 4, half-maximal inhibitory concentration: 5230 nM
Estimate against measurement, compound 4: 5.5-fold (0.74 log units) below, outside the stated range (above it).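

In this assay, the exchange of 4-methylbenzyl for 2-fluorobenzyl on the core of compound 2 gave a 1.8-fold higher number from compound 2 to compound 4 (0.27 log units; within the scatter), so the lowering seen on the core of compound 1 did not reappear. The two steps do not agree: the same change on two cores in this assay, a 3.1-fold lower number (0.50 log units; beyond the scatter) from compound 1 to compound 3 and a 1.8-fold higher number (0.27 log units; within the scatter) from compound 2 to compound 4, 5.8-fold (0.76 log units) apart, beyond the scatter of two such steps This shows that, for these two pairs, the effect of the exchange could not be carried from one core to the other, even though compound 1 and compound 2 themselves lie within the scatter of each other; it does not show why the two cores part ways, nor whether any other benzyl exchange would behave in the same way.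

The compounds shown leave open how a plain benzyl group or a chlorobenzyl group would fare on these two cores, which would tell whether the split is peculiar to 2-fluorobenzyl. Also open, from the compounds shown here alone, is whether the split would persist with a bromine in place of the chlorine on the core.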